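One Stereocentre Changed, Cytotoxicity Expected to Stay Flat

A few compounds are considered here, and "the series" means these few. Any claim that something is new, unique, unknown or untested is made for them only; others in the source may bear on it.

Compound 1, `CC1(COCc2ccc(OCc3ccccc3)cc2)Cn2cc([N+](=O)[O-])nc2S1`: in an ADME assay on L929 cells (Mus musculus) for cytotoxicity (a higher number here means a weaker inhibitor, a lower number a stronger inhibitor), compound 1 gives > 10 ug/mL, which is a limit of the assay rather than a number.
Compound 2, `CN1CC(OCc2ccc(OCc3ccccc3)cc2)Cn2nc([N+](=O)[O-])cc21`: in this assay compound 2 gives > 10 ug/mL, again a limit.
Compound 3, `O=[N+]([O-])c1cn2c(n1)[S@+]([O-])C[C@@H](OCc1ccc(OC(F)(F)F)cc1)C2`: in this assay compound 3 gives > 10 ug/mL, also a limit.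

Every value shown so far is a limit, as the evidence records: the limit of > 10 ug/mL in this assay, at which 3 of the 3 values shown sit. Compound 3 therefore stands exactly where the other two stand, at the limit, and nothing in these numbers sets it apart from compound 1 or compound 2.

Compound 4, `O=[N+]([O-])c1cn2c(n1)[S@+]([O-])C[C@H](OCc1ccc(OC(F)(F)F)cc1)C2`, has not yet been measured in this assay. It differs from compound 3 only in configuration: the two compounds have the same atoms and bonds and differ only in configuration as drawn: 1 of 2 stereo elements differ; a stereocentre at a saturated ring carbon is drawn S in compound 3 and R in compound 4.

Going by the values given here, no step between two measured compounds is available to show what such a change does here. With all three measured values sitting at the limit and no atom added or removed, the step from compound 3 to compound 4 is expected to be none beyond the scatter, as a step that the limit leaves unreadable from compound 3 to compound 4 expresses. Compound 4 is accordingly estimated to give about 20 ug/mL in this assay, with an expected range from 8 ug/mL to 60 ug/mL, most likely reported once more as a limit.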

Compound 4, half-maximal inhibitory concentration: > 10 ug/mL
Compound 4 gave a limit, no number; the forecaster's own chance of this, stated with the estimate: 85%; the middle value is on the limit's open side.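

No step can be read between compound 3 and compound 4, since in this assay each gives only a limit, not a number: the limit of > 10 ug/mL in this assay, at which 4 of the 4 values shown sit.

The compounds shown leave open whether the stereocentre at the saturated ring carbon, drawn S or R, makes any difference in this assay, and how far any of the four compounds lies past the limit.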